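Swapping the Ether Aryl: Cytotoxicity Outlook for Compound 4

The compounds below may be only part of what the source reports. "The series", "measured", "known", "first", "only" and "open" are said of these compounds alone.

Of the compounds shown here, three sharing one core have been measured in an ADME assay on MT4 cells (Homo sapiens) for cytotoxicity, read by MTT assay, with a stated time of 4 days; a lower number here means that less compound is tolerated, a higher number that more compound is tolerated. Compound 1 `Cc1cccc(C)c1Oc1nc(Nc2ccc(C#N)cc2)nc2ccccc12` gives 35000 nM; compound 2 `N#Cc1ccc(Nc2nc(Oc3ccc(Cl)cc3)c3ccccc3n2)cc1` gives 198000 nM; compound 3 `COc1ccccc1Oc1nc(Nc2ccc(C#N)cc2)nc2ccccc12` gives 150000 nM. Compound 3 therefore stands second highest of the three, close to compound 2 and well apart from compound 1. Compound 4 `Cc1ccc(Oc2nc(Nc3ccc(C#N)cc3)nc3ccccc23)cc1` differs from compound 3 in one place: 4-methylphenyl in place of 2-methoxyphenyl on an oxygen on an aromatic ring. Within the data shown here, the steps that bear on this are a 1.3-fold lower number from compound 2 to compound 3 (0.12 log units; within the scatter) and a 4.3-fold higher number from compound 1 to compound 3 (0.63 log units; beyond the scatter); the first shows that exchanging one phenyl group on that oxygen for another left this assay unchanged, while the second shows a modest shift. A step of no change at the digits printed from compound 3 to compound 4 (within the scatter) is expected. Compound 4 is estimated at 150000 nM, between 60000 nM and 300000 nM.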

Compound 4, half-maximal cytotoxic concentration: 87000 nM
Beside the measured number, compound 4's estimate is 1.7-fold (0.24 log units) above it, and the stated range covers the measured number.
By their numbers in this assay, from the lowest: compound 1; then compounds 4, 3 and 2 (each within the scatter of the next, the first and the last beyond it).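

In this assay, 4-methylphenyl in place of 2-methoxyphenyl on this oxygen gives a 1.7-fold lower number from compound 3 to compound 4 (0.24 log units; within the scatter) and so cannot be told apart from no change. Yet methyl in place of chloro on the same kind of ring gives a 2.3-fold lower number from compound 2 to compound 4 (0.36 log units; beyond the scatter) as a modest step, and 4-methylphenyl in place of 2,6-dimethylphenyl gives a 2.5-fold higher number from compound 1 to compound 4 (0.40 log units; beyond the scatter) as another, so small edits here can register beyond the scatter. No measured evidence explains these steps.

Still open, on these data alone, is how this assay would read with an amine or a carboxylic acid in place of the methyl of compound 4.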